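This account rests on a few compounds, and the source may have more. Where it says the series, first, only, none or still open, it means among the compounds named here.

Of the compounds shown here, three that share one core have been measured in a functional assay on MCF7 cells (Homo sapiens) for inhibition, read by MTT assay, with a stated time of 72 h; on this read-out lower numbers stand for stronger inhibition and higher numbers for weaker inhibition. Compound 1 `COc1ccc(-n2cc(CSC(=S)N3CCN(C(=O)OC(C)(C)C)CC3)nn2)cc1` gives 93100 nM, the highest of the three numbers. Compound 3 `S=C(SCc1cn(Cc2ccccc2Cl)nn1)N1CCNCC1` gives 38900 nM, the nearest to compound 1, with a gap that lies beyond the usual scatter. Compound 2 `O=C(OCc1ccccc1)N1CCN(C(=S)SCc2cn(Cc3ccc(F)cc3)nn2)CC1` gives 10300 nM, the furthest from compound 1, again beyond the scatter.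

Compound 4 `CC(C)(C)OC(=O)N1CCN(C(=S)SCc2cn(Cc3ccc(Cl)cc3)nn2)CC1` has not yet been measured. It differs from compound 1 in a single place: 4-chlorobenzyl in place of 4-methoxyphenyl on an aromatic nitrogen. Everything else in compound 1 is kept. Among the measured compounds shown here, no pair of measured compounds isolates this change, so its size cannot be read off directly. What can be said is that both measured compounds that carry a substituted benzyl group on that ring nitrogen, compound 2 and compound 3, show lower numbers than compound 1, although each of them also differs from compound 1 elsewhere in the molecule. On that basis a move to a lower number, beyond the scatter, is expected for compound 4, and the step from compound 1 to compound 4 is estimated at a 3.1-fold lower number from compound 1 to compound 4 (0.49 log units; beyond the scatter). Compound 4 is therefore expected to give about 30000 nM, within a range from 10000 nM to 90000 nM.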

Compound 4, half-maximal inhibitory concentration: 2960 nM
For compound 4 the middle estimate is 10-fold (1.01 log units) above the measured one; measured number below the stated range.
By their numbers in this assay, from the lowest: compound 4; then compound 2; then compound 3; then compound 1.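

In this assay, among the compounds shown here, the step of a 31-fold lower number from compound 1 to compound 4 (1.50 log units; beyond the scatter) comes from a change at one place, with the rest of compound 1 kept, so it is the first measured step here that isolates this position. It shows that the group on this aromatic nitrogen can by itself shift the number by a large amount, with no change anywhere else in the molecule. This shift occurs even though 4-methoxyphenyl and 4-chlorobenzyl match in heavy-atom count and each holds one six-membered aromatic ring of carbon only, and nothing measured here gives a reason for its size.

The step combines two differences, the added carbon link between the ring and the nitrogen and chlorine in place of methoxy on the ring, and the compounds shown cannot tell these apart, since neither 4-chlorophenyl nor 4-methoxybenzyl appears among them. They also leave open how far the trend runs on this nitrogen, for instance with a longer chain such as 2-phenylethyl, or with a ring carrying an amine or a carboxylic acid in place of the chlorine.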